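The compounds below may be only part of what the source reports. "The series", "measured", "known", "first", "only" and "open" are said of these compounds alone.

Values so far in a functional assay (Homo sapiens) for inhibition; on this read-out higher numbers stand for weaker inhibition and lower numbers for stronger inhibition:
Compound 1 `Fc1ccc(-c2[nH]c(SCc3ccccc3)nc2-c2ccncc2)cc1` gives 300 nM
Compound 2 `Fc1ccc(-c2[nH]c(SCCc3ccccc3)nc2-c2ccncc2)cc1` gives 640 nM
Compound 3 `Fc1ccc(-c2[nH]c(SCCCc3ccccc3)nc2-c2ccncc2)cc1` gives 470 nM

With a 1.6-fold higher number from compound 1 to compound 3 (0.19 log units; within the scatter) and a 1.4-fold lower number from compound 2 to compound 3 (0.13 log units; within the scatter) in hand, compound 3 stands within the scatter of both other compounds and cannot be ranked against them. Compound 4 `Fc1ccc(-c2[nH]c(SCC3CCCCC3)nc2-c2ccncc2)cc1` has cyclohexyl in place of phenethyl on a saturated chain carbon bound to a sulfur. Cut one bond further out, this reads 3-phenylpropyl to cyclohexylmethyl.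

The measured steps all change the chain and keep the phenyl ring, so they bear on this change only in part, and the data hold no direct comparison of the two ring types. Among the measured compounds shown here, with a 2.1-fold higher number from compound 1 to compound 2 (0.33 log units; beyond the scatter) as the only chain change beyond the scatter, no step beyond the scatter is expected in this assay for compound 4, although the missing ring comparison keeps the range wide. The expected outcome is a 1.2-fold lower number from compound 3 to compound 4 (0.07 log units; within the scatter) at the middle of the estimate. The expected value for compound 4 is 400 nM (range 150 nM to 1100 nM).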

Compound 4, half-maximal inhibitory concentration: 240 nM
Compound 4: the middle estimate sits 1.7-fold (0.22 log units) above what was measured; low and high end bracket the measured number.
By their numbers in this assay, from the lowest: compounds 4, 1, 3 and 2 (each within the scatter of the next, the first and the last beyond it).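

Among the compounds shown here, the first direct comparison of ring types comes with the swap of the phenyl ring for a cyclohexyl ring: in this assay, the step shows a 1.3-fold lower number from compound 1 to compound 4 (0.10 log units; within the scatter), so the non-aromatic ring cannot be told apart from the aromatic one at this place. For the compounds shown here, compound 4 also cannot be ranked against the longer phenyl chain of compound 3, with a 2.0-fold lower number from compound 3 to compound 4 (0.29 log units; within the scatter), but it does separate from compound 2, with a 2.7-fold lower number from compound 2 to compound 4 (0.43 log units; beyond the scatter), the only new step beyond the scatter. Nothing available here explains these results.

As far as these compounds go, it remains open whether cyclohexyl on a longer chain would follow the values seen for the phenyl series. Equally open, from the compounds shown here alone, is how an amine or a carboxylic acid on the cyclohexyl ring would read out here.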